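The compounds below may be only part of what the source reports. "The series", "measured", "known", "first", "only" and "open" are said of these compounds alone.

In a toxicity assay on THP-1 cells (Homo sapiens) for inhibition (a lower number here means that less compound is tolerated, a higher number that more compound is tolerated), compound 2 `COc1ccc(-c2cnc(NC(=O)c3ccc(F)cc3)n2C)cc1` stands only at a limit: >= 50000 nM. Compound 1 `COc1ccc(-c2cnc(NC(=O)c3ccc(F)cc3)n2Cc2ccccc2)cc1` also gives only a limit: > 100000 nM. Compound 3 `CCCCn1c(-c2ccc(OC)cc2)cnc1NC(=O)c1ccc(F)cc1` carries propyl in place of hydrogen on a saturated chain carbon bound to an aromatic nitrogen, that is, propyl in place of hydrogen on a saturated chain carbon bound to an aromatic nitrogen. For the measured compounds named here, the one measured step at this place is a step that the two limits leave unreadable from compound 1 to compound 2, so it gives no size to carry over. No step beyond the scatter is therefore expected in this assay, and a limit is again likely. The expected change is a step that the limit leaves unreadable from compound 2 to compound 3. Compound 3 is estimated at 70000 nM, with an expected range of 30000 nM to 150000 nM.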

Compound 3, half-maximal cytotoxic concentration: > 100000 nM
Compound 3: a limit, no number; the forecaster's own chance of this, stated with the estimate: 70%; at least 1.4-fold (0.15 log units) between middle value and limit.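

In this assay, for the compounds shown here, compound 1, compound 2 and compound 3 all give only limits, so no step among them can be read. On these data alone, whether the group at this place changes the tolerated concentration at all remains open.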